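From Methyl to Phenyl: Estimating Compound 4

The source may hold more compounds than are shown below. What is called first, only, known or untested is meant among the compounds shown, and "the series" means these compounds.

Three compounds share one core and differ only in the group on a single aromatic carbon. Compound 1 `COc1cc(-n2c(-c3ccccc3)csc2=S)cc(OC)c1OC` carries hydrogen there; in a functional assay on MCF7 cells (Homo sapiens) for cytotoxicity, read by MTT assay, with a stated time of 48 h (on this read-out higher numbers stand for weaker inhibition and lower numbers for stronger inhibition), compound 1 gives > 100 ug/mL, which is a limit of the assay rather than a number. Compound 2 `COc1cc(-n2c(-c3ccc(Br)cc3)csc2=S)cc(OC)c1OC` carries bromo; in this assay compound 2 gives > 100 ug/mL, again a limit and not a number. Among the compounds with values here, compound 3 `COc1cc(-n2c(-c3ccc(C)cc3)csc2=S)cc(OC)c1OC` carries methyl, and in this assay compound 3 gives 19.7 ug/mL, the only actual number among the three. The step from hydrogen to methyl is an at least 5.0-fold lower number from compound 1 to compound 3 (0.70 log units; beyond the scatter), and from bromo to methyl an at least 5.0-fold lower number from compound 2 to compound 3 (0.70 log units; beyond the scatter); the step that the two limits leave unreadable from compound 1 to compound 2 cannot be sized because of the limit of > 100 ug/mL in this assay, at which 2 of the 3 values shown sit. Compound 4 `COc1cc(-n2c(-c3ccc(-c4ccccc4)cc3)csc2=S)cc(OC)c1OC` changes compound 3 by phenyl in place of methyl on an aromatic carbon. Both readable steps concern this same place and show that methyl stands apart from hydrogen and bromo, but neither involves a phenyl, so the size of the new step has no direct anchor. Because (the limit of > 100 ug/mL in this assay, at which 2 of the 3 values shown sit), compound 4 is expected to come out weaker than compound 3, with an expected step of a 3.0-fold higher number from compound 3 to compound 4 (0.48 log units; beyond the scatter). The estimate for compound 4 in this assay is 60 ug/mL, between 12 ug/mL and 300 ug/mL, with a real chance that only a limit is reported.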

Compound 4, half-maximal inhibitory concentration: 45.3 ug/mL
Compound 4: the middle estimate sits 1.3-fold (0.12 log units) above what was measured; low and high end bracket the measured number.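

In this assay, phenyl in place of methyl gives a 2.3-fold higher number from compound 3 to compound 4 (0.36 log units; beyond the scatter), so a second group at this position now has a real number, and a much larger group with its own six-membered aromatic ring still leaves readable activity, though weaker than with methyl. Phenyl also stands apart from the other two groups, with an at least 2.2-fold lower number from compound 2 to compound 4 (0.34 log units; beyond the scatter) and an at least 2.2-fold lower number from compound 1 to compound 4 (0.34 log units; beyond the scatter), which means methyl is no longer the only group here that improves on hydrogen and bromo. These last two steps give only a lower bound on the true size, because each starts from a limit of the assay rather than a number: the limit of > 100 ug/mL in this assay, at which 2 of the 4 values shown sit.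

The four groups do not line up by size alone, since hydrogen and bromo both sit at the limit while methyl and phenyl, one small and one large, do not, so what separates them stays unexplained. On these data alone, an ethyl or methoxy group, or an amine, on this same aromatic carbon would help show whether the gain follows carbon groups in general, and how such groups compare with methyl remains open.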